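From a substituted phenyl amide to a pyridin-2-yl amide

The compounds below may be only part of what the source reports. "The series", "measured", "known", "first", "only" and "open" are said of these compounds alone.

Values from an in vitro ADME assay on microsomes from liver (Homo sapiens) for pharmacokinetics, read by LC-MS, with a stated time of 10 min, tested at 1 uM (a higher number here means faster removal of the compound, a lower number slower removal), are as follows
Compound 1 `CN1C[C@H](C(=O)Nc2ccc(F)cc2)[C@@H](c2ccc(/C=C/C(=O)Nc3ccccc3N)cc2)C1` gives 5 mL/min/kg
Compound 2 `Cc1cccc(NC(=O)[C@H]2CN(C)C[C@@H]2c2ccc(/C=C/C(=O)Nc3ccccc3N)cc2)c1` gives 14 mL/min/kg
Compound 3 `Cc1cc(NC(=O)[C@H]2CN(C)C[C@@H]2c2ccc(/C=C/C(=O)Nc3ccccc3N)cc2)ccc1F` gives 15 mL/min/kg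

Compound 3 sits at the upper end of this small set. The gap to its nearest neighbour, a 1.1-fold higher number from compound 2 to compound 3 (0.03 log units; within the scatter), lies within the scatter, while a 3.0-fold higher number from compound 1 to compound 3 (0.48 log units; beyond the scatter) is a modest step beyond it.

The next compound, compound 4 `CN1C[C@H](C(=O)Nc2ccccn2)[C@@H](c2ccc(/C=C/C(=O)Nc3ccccc3N)cc2)C1`, has not yet been measured. It carries pyridin-2-yl in place of 4-fluoro-3-methylphenyl on an amide-type nitrogen and otherwise keeps the shared core.

Going by the values given here, no measured compound has a ring with a hetero atom at this place, so no step measures the change directly. The nearest guide is a change to the same aromatic group, a 2.8-fold higher number from compound 1 to compound 2 (0.45 log units; beyond the scatter), which is also modest. The two compounds with the methyl, compound 2 and compound 3, both stand above compound 1, and none of the three goes against that. On these data alone, compound 4 has no methyl, so, going by compound 1 at 5 mL/min/kg, a move to a lower number is expected, though pyridin-2-yl itself is untested. The expected change is a 1.7-fold lower number from compound 3 to compound 4 (0.22 log units; within the scatter), which would remain within the scatter. In this assay compound 4 is estimated at 9 mL/min/kg, with an expected range from 4 mL/min/kg to 20 mL/min/kg.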

Compound 4, clearance: 8 mL/min/kg
Compound 4: the middle estimate sits 1.1-fold (0.05 log units) above what was measured, and the stated range covers the measured number.
By their numbers in this assay, from the lowest: compounds 1, 4, 2 and 3 (each within the scatter of the next, the first and the last beyond it).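

Pyridin-2-yl is the first ring with a hetero atom on this amide-type nitrogen, and in this assay it cannot be separated from any of the three phenyl amides (a 1.9-fold lower number from compound 3 to compound 4 (0.27 log units; within the scatter); a 1.8-fold lower number from compound 2 to compound 4 (0.24 log units; within the scatter); a 1.6-fold higher number from compound 1 to compound 4 (0.20 log units; within the scatter)). The earlier compounds shown here gave a clear split, with compound 2 and compound 3 each beyond the scatter of compound 1, but compound 4 carries no methyl and joins neither side, so the lack of a methyl does not by itself group a compound with compound 1. Nothing at hand explains this result, which rests on the numbers alone.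

The compounds shown leave open whether the ring nitrogen matters here at all, since an unsubstituted phenyl, which would separate that nitrogen from the fluoro and methyl groups, is not among them. On these data alone, it also remains open how pyridin-3-yl, pyrimidin-2-yl, a methyl-bearing pyridin-2-yl or a saturated ring such as cyclohexyl on the same amide-type nitrogen would stand against these four compounds.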